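Methyl added beside the indole nitrogen on compound 1

The compounds below may be only part of what the source reports. "The series", "measured", "known", "first", "only" and "open" are said of these compounds alone.

Among the compounds with values here, compound 1 `COC(=O)[C@@]1(C)CCC=C2[C@@H]1CC[C@@H](C)[C@]2(C)Cc1c[nH]c2ccc(OC)cc12` gives 1200 nM in a functional assay on HeLa cells (Homo sapiens) for inhibition, read by sulforhodamine B assay, with a stated time of 48 h (a higher number here means a weaker inhibitor of growth, a lower number a stronger inhibitor of growth), the lowest of the two numbers measured so far. Compound 2 `COC(=O)[C@@]1(C)CCC=C2[C@@H]1CC[C@@H](C)[C@]2(C)Cc1c[nH]c2ccc(C(F)(F)F)cc12` gives 11000 nM in this assay; the step of a 9.2-fold higher number from compound 1 to compound 2 (0.96 log units; beyond the scatter) is trifluoromethyl in place of methoxy on an aromatic carbon of the six-membered part of the fused system.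

Compound 3 `COC(=O)[C@@]1(C)CCC=C2[C@@H]1CC[C@@H](C)[C@]2(C)Cc1c(C)[nH]c2ccc(OC)cc12` differs from compound 1 only by methyl in place of hydrogen on an aromatic carbon. Within the data shown here, the single measured step concerns another group at another place of the fused system, so no measured step bears on this change directly. The methoxy of compound 1 is retained, and the change is a small one, so the step of a 1.3-fold higher number from compound 1 to compound 3 (0.10 log units; within the scatter) is expected to stay within the scatter, with no direction favoured. Compound 3 is therefore estimated at 1500 nM in this assay, within a range of 500 nM to 5000 nM.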

Compound 3, concentration for 50% growth inhibition: 12000 nM
For compound 3 the middle estimate is 8.0-fold (0.90 log units) below the measured one; measured number above the stated range.
By their numbers in this assay, from the lowest: compound 1; then compounds 2 and 3 (each within the scatter of the next).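

In this assay, methyl in place of hydrogen gives a 10-fold higher number from compound 1 to compound 3 (1.00 log units; beyond the scatter), so a single added carbon on the five-membered aromatic ring, next to the ring nitrogen and next to the ring atom that bears a large group, is enough to weaken growth inhibition beyond the scatter. This place therefore responds to substitution, and the earlier step, at another place of the fused system, gave no reading of it. No measurement at hand accounts for this loss.

The compounds shown leave open whether a chlorine, an ethyl or a hydroxymethyl at this same place would give a step of similar size to that of methyl. They also leave open whether the methyl step would hold with trifluoromethyl in place of the methoxy.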